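Urea aryl change: compound 3 to compound 4

A few compounds are considered here, and "the series" means these few. Any claim that something is new, unique, unknown or untested is made for them only; others in the source may bear on it.

Compound 3 `O=C(NCCCCC(c1ccc(F)cc1)c1ccc(F)cc1)Nc1cccc(Cl)c1` gives 5070 nM in a functional assay on MDA-MB-231 cells (Homo sapiens) for cytotoxicity, read by MTT assay, with a stated time of 48 h (a higher number here means a weaker inhibitor, a lower number a stronger inhibitor), and is the only one of the three measured compounds to return a number. Compound 1 `Fc1ccc(C(CCCCOCc2ccc(Oc3ccc(Cl)cc3)cc2)c2ccc(F)cc2)cc1` reaches only the limit of this assay, > 20000 nM. Compound 2 `Nc1ccc(NC(=O)NCCCCC(c2ccc(F)cc2)c2ccc(F)cc2)cc1` likewise reaches only the limit, > 20000 nM. Among the measured compounds shown here, the single measured step, an at least 3.9-fold lower number from compound 2 to compound 3 (0.59 log units; beyond the scatter), is therefore a lower bound on its own size, since it starts from the limit of > 20000 nM in this assay, at which 2 of the 3 values shown sit.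

Compound 4 `O=C(NCCCCC(c1ccc(F)cc1)c1ccc(F)cc1)Nc1ccc(Cl)cc1C(F)(F)F` differs from compound 3 by 4-chloro-2-(trifluoromethyl)phenyl in place of 3-chlorophenyl on an amide-type nitrogen. For the measured compounds named here, no measured step covers this exchange. The step from compound 2 to compound 3 alters the same aryl group but swaps an amino-bearing ring for a chlorophenyl, whereas here a chlorophenyl is replaced by another chlorophenyl carrying a trifluoromethyl; it gives no direction for the present change. The expectation is thus a step within the scatter, a 1.3-fold lower number from compound 3 to compound 4 (0.10 log units; within the scatter), with a wide range owing to the absence of a relevant precedent. Compound 4 is estimated at 4000 nM in this assay, between 1000 nM and 16000 nM.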

Compound 4, half-maximal inhibitory concentration: > 20000 nM
Compound 4 ended at the assay's limit; the forecaster's own chance of this, stated with the estimate: 20%; middle value at least 5.0-fold (0.69 log units) away from the limit.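

The exchange gives an at least 3.9-fold higher number from compound 3 to compound 4 (0.59 log units; beyond the scatter) in this assay, so a chlorine-bearing ring on this amide-type nitrogen does not by itself keep the measurable value of compound 3, which the step to compound 3 from the 4-aminophenyl compound 2 could not show. Compound 4 gives > 20000 nM, which is a limit of the assay and not a number, so the step fixes only a lower bound on the size of the change. The step between the two limit compounds cannot be read, and compound 3 remains the only compound with a number: the limit of > 20000 nM in this assay, at which 3 of the 4 values shown sit.

The compounds shown do not separate the entering trifluoromethyl from the changed place of the chlorine, as both change in this one exchange. Also open, on these data alone, is how a ring carrying a nitrile or a methoxy group in place of the chlorine would read in this assay.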